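Swapping the N-benzyl group for a fluoroindanyl in a sulfonamide

A few compounds are considered here, and "the series" means these few. Any claim that something is new, unique, unknown or untested is made for them only; others in the source may bear on it.

Measured so far:
Compound 1, `CC(C)CN(Cc1ccccc1C(F)(F)F)S(=O)(=O)c1ccc2c(c1)C(O)CC(C1CCOCC1)O2`: 4.23
Compound 2, `CCc1ccc(N(CC(C)C)S(=O)(=O)c2ccc3c(c2)C(O)CC(C(C)C2CCOCC2)O3)cc1`: 5.04
Compound 3, `Cc1ccc(N(C2CCC2)S(=O)(=O)c2ccc3c(c2)C(O)CC(C2CCOCC2)O3)c(C)c1`: 3.77

In a physicochemical assay for lipophilicity, at pH 7.4 (on this read-out higher numbers stand for higher lipophilicity and lower numbers for lower lipophilicity), compound 1 gives the second highest of these three values; compound 3 sits lower and compound 2 higher, both beyond the scatter. Compound 4, `CC(C)CN(C1CCc2ccc(F)cc21)S(=O)(=O)c1ccc2c(c1)C(O)CC(C1CCOCC1)O2`, has not yet been measured. It differs from compound 1 in one place: 6-fluoro-2,3-dihydro-1H-inden-1-yl in place of 2-(trifluoromethyl)benzyl on a sulfonamide nitrogen. Both groups carry no donors or acceptors, and the heavy-atom count hardly changes, so no step beyond the scatter is expected in this assay, with a slight lean downward if any. The estimated step of a number 0.13 log units lower from compound 1 to compound 4 (within the scatter) is therefore small. Compound 4 is expected to give about 4.1, most likely between 3.6 and 4.6.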

Compound 4, distribution coefficient: 3.94
Beside the measured number, compound 4's estimate is 0.16 log units above it; measured number inside the range.
By their numbers in this assay, from the lowest: compounds 3, 4 and 1 (each within the scatter of the next, the first and the last beyond it); then compound 2.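

Within the data shown here, measured in this assay the change gives a number 0.29 log units lower from compound 1 to compound 4 (within the scatter) and so offers the first direct comparison at this sulfonamide nitrogen, whose other neighbours are a saturated chain carbon and the sulfonyl sulfur. Here 6-fluoro-2,3-dihydro-1H-inden-1-yl can stand in place of 2-(trifluoromethyl)benzyl without a difference that repeated measurements could separate. No other measurement bears on the reason for this. Still open, as far as these compounds go, is whether a group of another kind at this place, such as an amine or a carboxylic acid, would move the number beyond the scatter.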